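The source may report more compounds than this note shows. Statements on the series, on what has been measured and on what is new or still open speak of the compounds shown alone.

Compound 1 `Cc1cc(O)cc(-c2nn(CC#N)cc2-c2ccnc(-c3ccc(Oc4ccccc4)cc3)c2)c1`: 4870 nM
Compound 2 `COc1cc(C)cc(-c2nn(CC#N)cc2-c2ccnc(-c3ccc(N(C)C)cc3)c2)c1`: 161 nM

Measured in a functional assay on K562 cells (Homo sapiens) for inhibition, read by sulforhodamine B assay, with a stated time of 48 h (on this read-out higher numbers stand for weaker inhibition of growth and lower numbers for stronger inhibition of growth), compound 2 stands at the lower of the two numbers, and compound 1 sits far higher, a gap well beyond the scatter. Compound 3 `Cc1cc(O)cc(-c2nn(CC#N)cc2-c2ccnc(-c3ccc(N(C)C)cc3)c2)c1` is not yet measured. It differs from compound 2 by hydrogen in place of methyl on an oxygen on an aromatic ring. For the measured compounds named here, no measured pair shows this change on its own; compound 1 also carries the hydroxy group but differs elsewhere too, so its number cannot be read as this step. In this assay a small step is expected, within or near the scatter and in either direction, giving a 1.4-fold higher number from compound 2 to compound 3 (0.14 log units; within the scatter). Compound 3 is estimated at 220 nM, with a range from 60 nM to 800 nM.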

Compound 3, concentration for 50% growth inhibition: 2550 nM
Compound 3: the middle estimate sits 12-fold (1.06 log units) below what was measured; measured number above the stated range.
By their numbers in this assay, from the lowest: compound 2; then compounds 3 and 1 (each within the scatter of the next).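

Here the methyl on the oxygen matters: hydrogen in place of methyl gives a 16-fold higher number from compound 2 to compound 3 (1.20 log units; beyond the scatter) and shows that, with the rest of the molecule unchanged, the methoxy group goes with far stronger growth inhibition than the hydroxy group. Once the hydroxy group is present, dimethylamino in place of phenoxy gives only a 1.9-fold lower number from compound 1 to compound 3 (0.28 log units; within the scatter) and so shows no clear effect of that swap. No measurement at hand explains the large step. Open, going by these compounds, is whether an ethoxy group or a fluorine at this place would match methoxy, and whether phenoxy would cost as little if the methoxy group were kept.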